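The compounds below may be only part of what the source reports. "The series", "measured", "known", "first", "only" and "open" are said of these compounds alone.

Compound 1 `CCOC(=O)C1=C(Nc2ccccc2)S/C(=C\c2ccc([N+](=O)[O-])c(O)c2)C1=O` gives 12700 nM
Compound 2 `CCOC(=O)C1=C(Nc2ccccc2)S/C(=C\c2cccc(C(=O)O)c2)C1=O` gives 11700 nM
Compound 3 `CCOC(=O)C1=C(Nc2ccccc2)S/C(=C\c2cc(OC)c(O)c(OC)c2)C1=O` gives 17400 nM

In a functional assay on JAR cells (Homo sapiens) for inhibition, read by MTT assay, with a stated time of 72 h (on this read-out higher numbers stand for weaker inhibition and lower numbers for stronger inhibition), compound 2 gives 11700 nM and stands within the scatter of both compound 1 and compound 3, so these three fall in no order. Compound 4 `CCOC(=O)C1=C(Nc2ccccc2)S/C(=C\c2ccc[nH]2)C1=O` is still unmeasured. Its change from compound 2 is 1H-pyrrol-2-yl in place of 3-carboxyphenyl on a double-bonded chain carbon bound to a double-bonded ring carbon with 1H-pyrrol-2-yl in place of 3-carboxyphenyl on a double-bonded chain carbon bound to a double-bonded ring carbon. Compound 1 at 12700 nM and compound 3 at 17400 nM bear other groups there than compound 2 and still sit within that scatter, so no shift beyond the scatter is expected in this assay for this swap. The estimated change is a 1.1-fold higher number from compound 2 to compound 4 (0.05 log units; within the scatter) and it is expected to stay within the scatter. For compound 4 the expected value is 13000 nM with an estimated range from 5000 nM to 32000 nM in all.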

Compound 4, half-maximal inhibitory concentration: 9500 nM
The estimate for compound 4 lay 1.4-fold (0.14 log units) above the measured number, and the stated range covers the measured number.
By their numbers in this assay, from the lowest: compounds 4, 2, 1 and 3 (each within the scatter of the next).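

In this assay, the swap of 3-carboxyphenyl for 1H-pyrrol-2-yl on a double-bonded chain carbon bound to a double-bonded ring carbon gives a 1.2-fold lower number from compound 2 to compound 4 (0.09 log units; within the scatter). For the compounds shown here, this is the first direct one-place comparison at this position, and it shows that a five-membered aromatic ring with one hetero atom and no carboxylic acid can stand in for the six-membered carbon ring without a shift beyond the scatter. Nothing available explains this result. The compounds shown leave open whether a non-aromatic group at this place, such as an aminoalkyl chain or a piperidine ring, would move the number beyond the scatter.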